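Thiophene exchange from compound 3 to compound 4

This account rests on a few compounds, and the source may have more. Where it says the series, first, only, none or still open, it means among the compounds named here.

In a functional assay on cells (Cancer cell lines, Homo sapiens) for inhibition (a higher number here means a weaker inhibitor of growth, a lower number a stronger inhibitor of growth), compound 3 (`Cc1cc(-c2nc3n(c2/C=N/NC(=N)N)CCS3)c(C)s1`) gives 30900 nM as the reference point for this step. Compound 2 (`Cc1cc(-c2nc3sccn3c2/C=N/NC(=N)N)c(C)s1`) gives 26900 nM in the same read-out, within the scatter of compound 3. Among the compounds with values here, compound 1 (`N=C(N)N/N=C/c1c(-c2cc(Cl)sc2Cl)nc2n1CCS2`) gives 15100 nM and is the one number beyond the scatter from compound 3.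

The change to compound 4 (`N=C(N)N/N=C/c1c(-c2cccs2)nc2n1CCS2`) is thiophen-2-yl in place of 2,5-dimethylthiophen-3-yl on an aromatic carbon with thiophen-2-yl in place of 2,5-dimethylthiophen-3-yl on an aromatic carbon.

Within the data shown here, only one measured step bears on this place: a 2.0-fold higher number from compound 1 to compound 3 (0.31 log units; beyond the scatter) for 2,5-dimethylthiophen-3-yl in place of 2,5-dichlorothiophen-3-yl, a modest change. Among the measured compounds shown here, no measured compound carries thiophen-2-yl, so the direction remains open. With that single modest step as the guide, no step beyond the scatter is expected in this assay here. The expected step is a 1.0-fold lower number from compound 3 to compound 4 (0.01 log units; within the scatter) on this reading. For compound 4 the estimated value is 30000 nM with an expected range from 14000 nM to 60000 nM in this read-out.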

Compound 4, concentration for total growth inhibition: 36300 nM
For compound 4 the middle estimate is 1.2-fold (0.08 log units) below the measured one; measured number inside the range.
By their numbers in this assay, from the lowest: compounds 1, 2, 3 and 4 (each within the scatter of the next, the first and the last beyond it).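

In this assay, thiophen-2-yl in place of 2,5-dimethylthiophen-3-yl on this aromatic carbon gives a 1.2-fold higher number from compound 3 to compound 4 (0.07 log units; within the scatter), so removing both methyl groups and moving the point of attachment together leaves the number unresolved from that of compound 3. Set against the 2,5-dichlorothiophen-3-yl group, the same thiophen-2-yl gives a 2.4-fold higher number from compound 1 to compound 4 (0.38 log units; beyond the scatter), which makes compound 1 the only one of the three compounds varied at this position to stand apart, with compound 3 and compound 4 together at the higher numbers. Nothing available explains why the dichlorinated thiophene differs from the other two groups.

Going by these compounds, whether the chlorine atoms or the thiophen-3-yl attachment carry that difference remains open, and an unsubstituted thiophen-3-yl would separate the two. A phenyl ring, an amine or a carboxylic acid at this carbon is also untested among the compounds shown.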